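The source may hold more compounds than are shown below. What is called first, only, known or untested is meant among the compounds shown, and "the series" means these compounds.

Measured in a functional assay on HL-60 cells (Homo sapiens) for cytotoxicity, read by WST assay, with a stated time of 48 h; on this read-out lower numbers stand for an effect already at smaller amounts and higher numbers for an effect only at larger amounts of compound:
- compound 1 `O=C1OC[C@H](Cc2ccccc2O)[C@H]1Cc1ccc(Cl)c(Cl)c1`: 33000 nM
- compound 2 `CCc1ccc(C[C@H]2COC(=O)[C@@H]2Cc2ccc(Cl)c(Cl)c2)cc1`: 16000 nM

Of these two numbers, compound 2 has the lower one, at 16000 nM. The next compound, compound 3 `O=C1OC[C@H](Cc2ccc(F)cc2)[C@H]1Cc1ccc(Cl)c(Cl)c1`, keeps the shared core but carries 4-fluorophenyl in place of 4-ethylphenyl: fluoro in place of ethyl on an aromatic carbon. The change sits on an aromatic carbon, para to a large group.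

For the measured compounds named here, only one measured step bears on this, and it concerns the same aromatic ring. Putting 4-ethylphenyl in place of 2-hydroxyphenyl gave a 2.1-fold lower number from compound 1 to compound 2 (0.31 log units; beyond the scatter), a modest change. Going by the values given here, no measured compound carries fluoro, so that step is only a rough guide to size and says little about direction. In this assay, a small shift towards a higher number is expected, keeping compound 3 near the two measured compounds. The expected change is a 1.4-fold higher number from compound 2 to compound 3 (0.14 log units; within the scatter). For compound 3 the estimated value is 22000 nM, with an expected range of 10000 nM to 48000 nM.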

Compound 3, half-maximal effective concentration: 14000 nM
For compound 3 the middle estimate is 1.6-fold (0.20 log units) above the measured one; measured number inside the range.
By their numbers in this assay, from the lowest: compounds 3 and 2 (each within the scatter of the next); then compound 1.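

In this assay, the step from ethyl to fluoro on this aromatic carbon makes no clear difference (a 1.1-fold lower number from compound 2 to compound 3 (0.06 log units; within the scatter)), so a single fluorine and the larger ethyl group cannot be told apart here. The step from 2-hydroxyphenyl to 4-fluorophenyl is modest but beyond the scatter (a 2.4-fold lower number from compound 1 to compound 3 (0.37 log units; beyond the scatter)), which gives a second ring that stands apart from compound 1 in the same direction, as 4-ethylphenyl did. Nothing measured here explains either result.

Still open, going by these compounds, is whether this position tolerates groups of other kinds, such as an amine, a carboxylic acid or a longer chain than ethyl. It is also unclear whether any group there could move the number well away from the narrow range seen so far.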